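The compounds below may be only part of what the source reports. "The series", "measured", "known", "first", "only" and "open" are said of these compounds alone.

Of the compounds shown here, three sharing one core have been measured in an ADME assay on Vero cells (Chlorocebus sabaeus) for cytotoxicity, read by MTT assay, with a stated time of 72 h; a lower number here means a stronger inhibitor, a higher number a weaker inhibitor. In it, compound 1 `CC(=O)c1c(C(F)(F)F)[n+]([O-])c2cc(-n3ccnc3)c(F)cc2[n+]1[O-]` gives 46500 nM, compound 2 `CCOC(=O)c1c(C)[n+]([O-])c2cc(-n3ccnc3)c(F)cc2[n+]1[O-]` gives 129000 nM, and compound 3 `CCOC(=O)c1c(C(F)(F)F)[n+]([O-])c2cc(N3CCNCC3)c(F)cc2[n+]1[O-]` gives 31300 nM. Compound 3 therefore sits within the usual scatter of compound 1, so these two cannot be told apart, while compound 2 has a higher number than compound 3, a gap beyond that scatter.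

Compound 4 `CCOC(=O)c1c(C(F)(F)F)[n+]([O-])c2cc(-n3ccnc3)c(F)cc2[n+]1[O-]` departs from compound 3 in one place, with 1H-imidazol-1-yl in place of piperazin-1-yl on an aromatic carbon, ortho to a fluoro group: 1H-imidazol-1-yl in place of piperazin-1-yl on an aromatic carbon. Among the compounds with values here, no two measured compounds differ in only one place, so the effect of this swap has not been seen on its own, and any guidance is indirect. Compound 4 shares its 1H-imidazol-1-yl and trifluoromethyl groups with compound 1, at 46500 nM. Compound 2 also carries 1H-imidazol-1-yl but has no trifluoromethyl group, and it stands at 129000 nM. The expected change is a small one toward a higher number, probably not beyond the scatter, with an estimated step of a 1.6-fold higher number from compound 3 to compound 4 (0.20 log units; within the scatter). The estimated value for compound 4 is 50000 nM, with a likely range from 20000 nM to 120000 nM.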

Compound 4, half-maximal inhibitory concentration: 19400 nM
For compound 4 the middle estimate is 2.6-fold (0.41 log units) above the measured one; the whole stated range lies above it.
By their numbers in this assay, from the lowest: compounds 4, 3 and 1 (each within the scatter of the next, the first and the last beyond it); then compound 2.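

In this assay, replacing piperazin-1-yl with 1H-imidazol-1-yl on this aromatic carbon, ortho to a fluoro group, gives a 1.6-fold lower number from compound 3 to compound 4 (0.21 log units; within the scatter), so this position accepts either ring with no detectable change, even though one is a six-membered non-aromatic ring with a hydrogen-bond donor and the other a five-membered aromatic ring without one. Within the data shown here, compound 4 also provides the first one-place comparisons at two other sites: trifluoromethyl in place of methyl on an aromatic carbon gives a 6.6-fold lower number from compound 2 to compound 4 (0.82 log units; beyond the scatter), and ethoxy in place of methyl on a carbonyl carbon gives a 2.4-fold lower number from compound 1 to compound 4 (0.38 log units; beyond the scatter), so, unlike the ring swap, both of these changes register beyond the scatter. No supporting measurement is available to explain the size of any of these steps.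

The compounds shown leave open whether an open-chain group such as dimethylamino, or a different ring such as morpholin-4-yl, would fit the same picture on this carbon. They also leave open whether the two rings would still match if the trifluoromethyl were replaced by methyl or the ethoxy by methyl.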